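The source may report more compounds than this note shows. Statements on the series, on what has been measured and on what is new or still open speak of the compounds shown alone.

Measured so far:

- compound 1, `C[C@H](NC(=O)c1nnn(Cc2cccc(C(F)(F)F)c2)c1C(F)(F)F)c1ccc(C(=O)O)cc1`: > 10000 nM
- compound 2, `C[C@H](NC(=O)c1nnn(CCOc2ccc(F)cc2)c1C(F)(F)F)c1ccc(C(=O)O)cc1`: > 10000 nM
- compound 3, `C[C@H](NC(=O)c1c(C(F)(F)F)nnn1Cc1cccc(C(F)(F)F)c1)c1ccc(C(=O)O)cc1`: 1970 nM

The three compounds were tested in a functional assay on CHO cells for antagonist activity at prostaglandin E2 receptor EP4 subtype (Homo sapiens), read by calcium flux, with a stated time of 15 min; on this read-out higher numbers stand for weaker inhibition and lower numbers for stronger inhibition. In this assay compound 1 gives no number, only the limit > 10000 nM. Compound 2 likewise gives only the limit > 10000 nM. For the measured compounds named here, compound 3 is the one compound of the three with a read number, 1970 nM in this assay.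

Compound 1 and compound 2 differ in one place: (4-fluorophenoxy)methyl in place of 3-(trifluoromethyl)phenyl on a saturated chain carbon bound to an aromatic nitrogen. Both sit at the limit of > 10000 nM in this assay, at which 2 of the 3 values shown sit, so the step that the two limits leave unreadable from compound 1 to compound 2 cannot be sized from the two values. Compound 1 and compound 3 share the same atoms joined differently; the difference between the two cores is not broken down here.

Compound 4, `C[C@H](NC(=O)c1c(C(F)(F)F)nnn1CCOc1ccc(F)cc1)c1ccc(C(=O)O)cc1`, is not yet measured. It stands to compound 3 as compound 2 stands to compound 1: (4-fluorophenoxy)methyl in place of 3-(trifluoromethyl)phenyl on a saturated chain carbon bound to an aromatic nitrogen. The place is described in the same words for both pairs, so this is the same change made on the core of compound 3 instead of the core of compound 1. Because the limit of > 10000 nM in this assay, at which 2 of the 3 values shown sit, hides the size of the earlier step, there is no measured guide to how large the step from compound 3 to compound 4 might be in this assay. The expectation is therefore anchored on compound 3 alone, with wide room on either side. For compound 4 an inhibitory concentration near 4000 nM is expected in this assay, which would mean an estimated step of a 2.0-fold higher number from compound 3 to compound 4 (0.31 log units; beyond the scatter), with a considerable chance that only a limit is reported.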

Compound 4, half-maximal inhibitory concentration: 276 nM
Estimate against measurement, compound 4: 14-fold (1.16 log units) above; the whole stated range lies above it.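

In this assay, replacing 3-(trifluoromethyl)benzyl with 2-(4-fluorophenoxy)ethyl gives a 7.1-fold lower number from compound 3 to compound 4 (0.85 log units; beyond the scatter), a shift toward stronger inhibition that is larger than the usual scatter between repeated measurements. The same replacement on the core of compound 1 cannot be read, because compound 1 and compound 2 both give only a limit rather than a number: the limit of > 10000 nM in this assay, at which 2 of the 4 values shown sit. The result therefore shows what this replacement does on one core, but it does not show whether the change carries over to the other core with the same size or even in the same direction.

The compounds shown also leave open which part of the replacement goes with the lower number, since the trifluoromethyl group leaves while an oxygen in the chain and a fluorine on the ring enter in a single step. A 2-phenoxyethyl group, with no fluorine on the ring, or a longer chain such as 3-(4-fluorophenoxy)propyl, placed on the core of compound 3, would begin to separate these parts and test how much the length of the chain matters.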